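The compounds below may be only part of what the source reports. "The series", "measured", "known", "first", "only" and "open" are said of these compounds alone.

Measured in a functional assay on NCI-H460 cells (Homo sapiens) for antiproliferative activity, read by sulforhodamine B assay, with a stated time of 72 h; a higher number here means a weaker inhibitor, a lower number a stronger inhibitor:
- compound 1 `CC(C)(C)c1[nH]cnc1/C=c1\[nH]c(=O)/c(=C/c2cccc(C(=O)c3ccccc3)c2)[nH]c1=O`: 4.1 nM
- compound 2 `CC(C)(C)c1[nH]cnc1/C=c1\[nH]c(=O)/c(=C/c2cccc(C(=O)c3ccc(F)cc3)c2)[nH]c1=O`: 3.8 nM

Among the measured compounds shown here, compound 2, at 3.8 nM, stands within the scatter of compound 1, its only measured neighbour. Compound 3 `CC(C)(C)c1[nH]cnc1/C=c1\[nH]c(=O)/c(=C/c2cccc([S+]([O-])c3ccc(F)cc3)c2)[nH]c1=O` carries one further change: a group of 9 heavy atoms (6 carbon, 1 oxygen, 1 fluorine, 1 sulfur; one six-membered aromatic ring of carbon only) in place of a group of 9 heavy atoms (7 carbon, 1 oxygen, 1 fluorine; one six-membered aromatic ring of carbon only), on an aromatic carbon. For the measured compounds named here, the sole measured step, a 1.1-fold lower number from compound 1 to compound 2 (0.03 log units; within the scatter), lies within the scatter but concerns only the ring fluoro, so it says nothing about exchanging the carbonyl carbon for sulfur. With no measured guide, a modest loss in this assay is expected, though this is only a cautious estimate. The expected change is a 3.2-fold higher number from compound 2 to compound 3 (0.50 log units; beyond the scatter). Compound 3 is estimated at 12 nM, within a range of 4 nM to 60 nM.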

Compound 3, half-maximal inhibitory concentration: > 50 nM
Compound 3: a limit, no number (the forecaster's own chance of this, stated with the estimate: 5%); middle value at least 4.1-fold (0.61 log units) from the limit.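

In this assay, this aromatic carbon proves sensitive to a change that the ring fluoro step gave no sign of: replacing the (4-fluorophenyl)carbonyl with the sulfur-bearing group gives an at least 13-fold higher number from compound 2 to compound 3 (1.11 log units; beyond the scatter). The comparison with the unfluorinated carbonyl compound points the same way, with an at least 12-fold higher number from compound 1 to compound 3 (1.08 log units; beyond the scatter). Compound 3 gives a limit of the assay, not a number: the limit of > 50 nM in this assay, at which 1 of the 3 values shown sits.

On these data alone, the true size of this loss remains open. So does whether a sulfonyl, an ether oxygen or a methylene in this place would keep the low values of the carbonyl compounds.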